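The source may hold more compounds than are shown below. What is called first, only, known or untested is meant among the compounds shown, and "the series" means these compounds.

In a functional assay on A549 cells (Homo sapiens) for inhibition, read by MTT assay, with a stated time of 48 h (on this read-out lower numbers stand for stronger inhibition and higher numbers for weaker inhibition), compound 1 `COc1cc2c(cc1OC)CN(C(=O)CN1C(=O)S/C(=C\c3nc4ccccc4n3C(C)C)C1=O)CC2` gives 20600 nM. For the measured compounds named here, compound 2 `CC1CN(C(=O)CN2C(=O)S/C(=C\c3nc4ccccc4n3C)C2=O)CC(C)O1` gives 29400 nM in this assay, a number that sits within the usual scatter of the one for compound 1, so the two cannot be ranked. Compound 3 `CC1CN(C(=O)CN2C(=O)S/C(=C\c3nc4ccccc4n3C(C)C)C2=O)CC(C)O1` is reported in this assay only as a limit, > 50000 nM, and not as a number. That value is the limit of > 50000 nM in this assay, at which 1 of the 3 values shown sits.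

Compound 3 and compound 2 differ in a single place, (methyl in place of isopropyl on an aromatic nitrogen), and this change gave an at least 1.7-fold lower number from compound 3 to compound 2 (0.23 log units; that floor lies within the scatter). Compound 1 and compound 3 differ in more than one place, and the difference between the two cores is not broken down here.

Compound 4 `COc1cc2c(cc1OC)CN(C(=O)CN1C(=O)S/C(=C\c3nc4ccccc4n3C)C1=O)CC2` has not yet been measured. Going by the values given here, it differs from compound 1 by methyl in place of isopropyl on an aromatic nitrogen, the same change as the one from compound 3 to compound 2, made on the same place of the five-membered ring. On the core of compound 1 the step is expected to run in the same direction but to stay modest, because the measured step of an at least 1.7-fold lower number from compound 3 to compound 2 (0.23 log units; that floor lies within the scatter) is known only as a floor. The account therefore expects a 1.6-fold lower number from compound 1 to compound 4 (0.20 log units; within the scatter). In this assay compound 4 is estimated to give 13000 nM, with a likely range from 5000 nM to 32000 nM.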

Compound 4, half-maximal inhibitory concentration: 13400 nM
Compound 4: the middle estimate sits 1.0-fold (0.01 log units) below what was measured; the range from low to high includes it.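

In this assay, methyl in place of isopropyl on the aromatic nitrogen gave a 1.5-fold lower number from compound 1 to compound 4 (0.19 log units; within the scatter), so on the core of compound 1 this change shows no effect that can be told apart from repeat-to-repeat variation. On the two cores the change points the same way, which fits its carrying over, but this does not establish that the step has the same size on both, and the step on the other core could be larger than its floor: the same change on two cores in this assay, an at least 1.7-fold lower number (0.23 log units; that floor lies within the scatter) from compound 3 to compound 2 and a 1.5-fold lower number (0.19 log units; within the scatter) from compound 1 to compound 4; the limit leaves it open whether they differ. Compound 3 is known only as a limit, so one end of that comparison has no number: the limit of > 50000 nM in this assay, at which 1 of the 4 values shown sits.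

The compounds shown leave open how an ethyl or a benzyl group on that aromatic nitrogen would read in this assay, and whether any group there would give a step beyond the scatter. They also leave open whether a longer chain ending in an amine or a carboxylic acid at the same place would behave like methyl and isopropyl, and whether the step would look alike on a third core.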